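Amino for cyano on the shared core

The source may hold more compounds than are shown below. What is called first, only, known or untested is meant among the compounds shown, and "the series" means these compounds.

In a functional assay on SK-OV-3 cells (Homo sapiens) for inhibition, read by MTT assay (a lower number here means a stronger inhibitor, a higher number a weaker inhibitor), compound 1 (`COc1ccc(/C=C2\c3cc(OC)c(OC)c(OC)c3CC[C@H]2O)cc1F`) gives 720 nM and compound 2 (`COc1ccc(/C=C2\c3cc(OC)c(OC)c(OC)c3CC[C@H]2O)cc1C#N`) gives 600 nM, so compound 2 stands level with compound 1 within the scatter. Compound 3 (`COc1ccc(/C=C2\c3cc(OC)c(OC)c(OC)c3CC[C@H]2O)cc1N`) has amino in place of cyano on an aromatic carbon, ortho to a methoxy group: amino in place of cyano on an aromatic carbon. Among the compounds with values here, the only measured step at this place is a 1.2-fold lower number from compound 1 to compound 2 (0.08 log units; within the scatter), cyano in place of fluoro, and it stays within the scatter. Within the data shown here, no measured compound carries amino here, so the data give only indirect guidance. In this assay, no change beyond the scatter is expected, and the estimated step is a 1.5-fold lower number from compound 2 to compound 3 (0.18 log units; within the scatter). The range is left wide, especially toward lower numbers. For compound 3 the estimated value is 400 nM, with an expected range of 60 nM to 1000 nM.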

Compound 3, half-maximal inhibitory concentration: 1870 nM
Beside the measured number, compound 3's estimate is 4.7-fold (0.67 log units) below it, and the stated range ends below it.
By their numbers in this assay, from the lowest: compounds 2 and 1 (each within the scatter of the next); then compound 3.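

In this assay this position no longer looks indifferent to its substituent: fluoro and cyano could not be told apart, but amino raises the number beyond the scatter against both (amino for cyano: a 3.1-fold higher number from compound 2 to compound 3 (0.49 log units; beyond the scatter); amino for fluoro: a 2.6-fold higher number from compound 1 to compound 3 (0.41 log units; beyond the scatter)). Amino is therefore the less favourable group of the three at this aromatic carbon, and the step from cyano also brings in a hydrogen-bond donor where cyano has none. Nothing available accounts for the higher number.

As far as these compounds go, whether it follows from that donor or from amino itself remains open, and a hydroxyl group or a methylamino group at this place would help to separate the two. An acetylamino group would show whether capping the nitrogen restores the level seen with fluoro and cyano.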